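Tosylating the free phenol of a triazole-bearing core

A few compounds are considered here, and "the series" means these few. Any claim that something is new, unique, unknown or untested is made for them only; others in the source may bear on it.

Measured so far in a functional assay on MCF7 cells (Homo sapiens) for cytotoxicity, read by MTT assay, with a stated time of 4 days; a lower number here means a stronger inhibitor, a higher number a weaker inhibitor:
- compound 1 `C=C1C(=O)[C@]23C[C@@]1(O)CC[C@H]2c1ccc(OS(=O)(=O)c2ccc(C)cc2)c(C)c1[C@@H]3Cn1cc(-c2ccccn2)nn1` gives 320 nM
- compound 2 `C=C1C(=O)[C@]23C[C@@]1(O)CC[C@H]2c1ccc(O)c(C)c1[C@@H]3Cn1cc(-c2ccc(F)cc2)nn1` gives 1700 nM

Compound 2 has the highest number of the two, and its nearest neighbour, compound 1, sits well beyond the scatter with its lower value. Among the compounds with values here, the two compounds differ in two places, not one, so no single step between them can be read off.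

Compound 3 `C=C1C(=O)[C@]23C[C@@]1(O)CC[C@H]2c1ccc(OS(=O)(=O)c2ccc(C)cc2)c(C)c1[C@@H]3Cn1cc(-c2ccc(F)cc2)nn1` is not yet measured. It is compound 2 with one change: (4-methylphenyl)sulfonyl in place of hydrogen on an oxygen on an aromatic ring, which means hydroxy becomes ((4-methylphenyl)sulfonyl)oxy on the shared core. Within the data shown here, no measured pair isolates this change. Among the measured compounds shown here, the only guide is that compound 1, which also carries the (4-methylphenyl)sulfonyl group on that oxygen, shows the lower number, 320 nM, though it also differs elsewhere.

In this assay the step from compound 2 to compound 3 is expected to be a 2.8-fold lower number from compound 2 to compound 3 (0.45 log units; beyond the scatter), moving toward a lower number, with real uncertainty. For compound 3 the estimated value is 600 nM, expected to fall between 180 nM and 2000 nM.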

Compound 3, half-maximal inhibitory concentration: 330 nM
For compound 3 the middle estimate is 1.8-fold (0.26 log units) above the measured one; the measured number falls inside the stated range.
By their numbers in this assay, from the lowest: compounds 1 and 3 (each within the scatter of the next); then compound 2.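

In this assay, the hydroxy group on the shared core can now be compared directly with ((4-methylphenyl)sulfonyl)oxy. Placing (4-methylphenyl)sulfonyl in place of hydrogen on this oxygen on an aromatic ring gives a 5.2-fold lower number from compound 2 to compound 3 (0.71 log units; beyond the scatter), a difference that the earlier pair could not isolate because its members differed in two places. The second one-place comparison, with 4-fluorophenyl in place of pyridin-2-yl on an aromatic carbon, gives a 1.0-fold higher number from compound 1 to compound 3 (0.01 log units; within the scatter), so with (4-methylphenyl)sulfonyl on the oxygen, this exchange leaves the result within the usual scatter of this assay.

As far as these compounds go, it remains open whether the same exchange would also make no clear difference with the free hydroxy group in place, and whether a smaller group on the oxygen, such as methyl, acetyl or methanesulfonyl, would give a similar result. Nothing in the available data explains why the (4-methylphenyl)sulfonyl change lowers the number in these cells.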